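The source may report more compounds than this note shows. Statements on the series, on what has been measured and on what is new or still open speak of the compounds shown alone.

Compound 1 `COc1ccc([C@H]2CC(=O)N(C(=O)c3ccccc3)C2)cc1OC1CCCC1`: > 10000 nM
Compound 2 `COc1ccc([C@H]2CC(=O)N(c3ccc(C#N)cc3)C2)cc1OC1CCCC1`: > 10000 nM

In a functional assay on HEK293 cells (Homo sapiens) for cytotoxicity (on this read-out higher numbers stand for lower toxicity in this test and lower numbers for higher toxicity in this test), compound 1 gives > 10000 nM, a limit of the assay rather than a number. Compound 2 likewise gives > 10000 nM, again a limit. The step that the two limits leave unreadable from compound 1 to compound 2 therefore cannot be read, because both values sit at the limit of > 10000 nM in this assay, at which 2 of the 2 values shown sit.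

Compound 3 `COc1ccc([C@H]2CC(=O)N(c3ccc(C(F)(F)F)cc3)C2)cc1OC1CCCC1` differs from compound 1 by 4-(trifluoromethyl)phenyl in place of benzoyl on an amide-type nitrogen in a ring. Among the measured compounds shown here, the only measured step that bears on this exchange is the one from compound 1 to compound 2, and its size is not readable, so no direction can be inferred from it. Compound 3 is estimated to give 20000 nM, in the range 7000 nM to 60000 nM, meaning an expected step that the limit leaves unreadable from compound 1 to compound 3 that is likely again only a limit.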

Compound 3, half-maximal cytotoxic concentration: > 10000 nM
Compound 3: no number, only a limit; the forecaster's own chance of this, stated with the estimate: 80%; the middle value does not contradict the limit.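

In this assay compound 3 gives > 10000 nM, again a limit of the assay. Among the compounds shown here, no step among compound 1, compound 2 and compound 3 can be read, because all three share one limit: the limit of > 10000 nM in this assay, at which 3 of the 3 values shown sit. The compounds shown leave open whether these groups on the amide-type nitrogen differ at all in cytotoxicity.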